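Adding a methyl to compound 2

A few compounds are considered here, and "the series" means these few. Any claim that something is new, unique, unknown or untested is made for them only; others in the source may bear on it.

In a functional assay on PC-3 cells (Homo sapiens) for cytotoxicity (a lower number here means a stronger inhibitor, a higher number a weaker inhibitor), compound 1 `COc1ccc2nc(NC(=O)CCCCC(=O)NO)sc2c1` gives 15.3 ug/mL, while compound 2 `O=C(CCCCCCC(=O)Nc1nc2ccccc2s1)NO` gives 5.44 ug/mL, the lower of the two numbers, with a gap beyond the scatter. Compound 3 `Cc1ccc2nc(NC(=O)CCCCCCC(=O)NO)sc2c1` is compound 2 with methyl in place of hydrogen on an aromatic carbon. Among the measured compounds shown here, no measured pair shows such a change, so only a small effect is expected. The estimated step of a 1.1-fold lower number from compound 2 to compound 3 (0.04 log units; within the scatter) is expected to stay within the scatter, with no clear direction. For compound 3 the expected value in this assay is 5 ug/mL, with an estimated range of 2 ug/mL to 12 ug/mL.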

Compound 3, half-maximal inhibitory concentration: 0.53 ug/mL
For compound 3 the middle estimate is 9.4-fold (0.97 log units) above the measured one; measured number below the stated range.
By their numbers in this assay, from the lowest: compound 3; then compound 2; then compound 1.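

In this assay, methyl in place of hydrogen on an aromatic carbon gives a 10-fold lower number from compound 2 to compound 3 (1.01 log units; beyond the scatter), so this position on the shared core, meta to a fused ring and para to a fused ring, is sensitive to substitution. This is the only step shown that isolates one change, and it is large for an entering group of 1 heavy atom. Nothing measured here bears on the reason for this effect. Going by these compounds, whether an ethyl group or a chlorine atom on this same carbon would give a similar number remains open. So does whether the methyl would keep its effect with a longer chain.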